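Phenyl for propyl on the chain carbon, two parallel steps

The source may hold more compounds than are shown below. What is called first, only, known or untested is meant among the compounds shown, and "the series" means these compounds.

Compound 1 `C=CCn1c(=O)n(CCCC)c2nc(N)nc(O)c21` and compound 2 `C=CCn1c(=O)n(Cc2ccccc2)c2nc(N)nc(O)c21` share one core; compound 3 `CCCCn1c(=O)n(C2OC(CO)[C@@H](O)[C@H]2O)c2nc(N)nc(O)c21` carries another core, and the difference between the two cores is not broken down here. In a functional assay on the whole organism (B cells) with Mus musculus as the target (on this read-out higher numbers stand for larger maximal responses and lower numbers for smaller maximal responses), compound 1 gives 77%, compound 2 gives 25% and compound 3 gives 86%. The values of compound 3 and compound 1 lie within the scatter of each other, while compound 2 sits beyond the scatter below both.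

Within the data shown here, the one counted step among the measured compounds, (phenyl in place of propyl on a saturated chain carbon bound to an aromatic nitrogen), gives a number 52 percentage points lower from compound 1 to compound 2 (beyond the scatter). Compound 4 `Nc1nc(O)c2c(n1)n(C1OC(CO)[C@@H](O)[C@H]1O)c(=O)n2Cc1ccccc1` is not yet measured; it differs from compound 3 by phenyl in place of propyl on a saturated chain carbon bound to an aromatic nitrogen, the same change at the same place as that between compound 1 and compound 2, so the change occurs twice in the series. Nothing beyond these two pairs shows how it behaves on other cores.

Beside the earlier step, the step expected here is a number 46 percentage points lower from compound 3 to compound 4 (beyond the scatter). This rests on the earlier pair, where the step was a number 52 percentage points lower from compound 1 to compound 2 (beyond the scatter), and on compound 3 starting from 86%. Since the core of compound 3 is not that of compound 1, the expected drop is given a wide band. Compound 4 is thus estimated at 40%, with a band from 15% to 70%.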

Compound 4, largest response reached (reported as maximal response), in percent of the reference or control that the assay uses: 110%
Beside the measured number, compound 4's estimate is 70 percentage points below it; measured number above the stated range.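

In this assay, phenyl in place of propyl on a saturated chain carbon bound to an aromatic nitrogen gives a number 24 percentage points higher from compound 3 to compound 4 (beyond the scatter), so on the core of compound 3 the change raises the maximal response. Set beside the pair on the other core, the change does not carry over as a fixed step, and even its direction differs between the two cores: the same change on two cores in this assay, a number 52 percentage points lower (beyond the scatter) from compound 1 to compound 2 and a number 24 percentage points higher (beyond the scatter) from compound 3 to compound 4, 76 percentage points apart, beyond the scatter of two such steps

This shows that, in this series, a step read on one core is a poor guide to the step on the other, but two pairs give no rule, and the data do not tell which difference between the cores goes with the reversal or what the change would do on a third core.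

The compounds shown hold only butyl and benzyl at this place, which leaves open whether a longer chain such as octyl would follow the butyl compounds or the benzyl compounds on either core. From the compounds shown here alone, it also remains open how a benzyl group carrying an amine or a carboxylic acid would behave in this assay, and whether such a group would show the same split between the two cores.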